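Ethoxycarbonyl for Furan-2-yl on a Shared Core

This account rests on a few compounds, and the source may have more. Where it says the series, first, only, none or still open, it means among the compounds named here.

compound 1 `O=[N+]([O-])c1ccc(-c2nss/c2=N\c2ccccc2)cc1`: 0%
compound 2 `c1ccc(/N=c2\ssnc2-c2ccco2)cc1`: 0%
compound 3 `Cc1nss/c1=N\c1ccccc1`: 0%

All three values were read in a functional assay on MDA-MB-231 cells (Homo sapiens) for antiproliferative activity, read by MTT assay, with a stated time of 72 h, tested at 10 uM; a higher number here means more inhibition at the concentration tested (going by the name of the read-out), a lower number less inhibition. Compound 2 stands level with compound 1 and compound 3 at the digits given; its nearest neighbour is compound 1 and its furthest compound 3, and in neither case does the gap exceed the scatter. Among the measured compounds shown here, the one measured step that alters the same aromatic carbon, no change at the digits printed from compound 2 to compound 3 (within the scatter), replaced the furan-2-yl with a methyl and left the read-out unchanged.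

The next compound, compound 4 `CCOC(=O)c1nss/c1=N\c1ccccc1`, differs from compound 2 by ethoxycarbonyl in place of furan-2-yl on an aromatic carbon.

That earlier step bears on the present one. The exchange sits on the same aromatic carbon, and it showed no change (no change at the digits printed from compound 2 to compound 3 (within the scatter)). For the measured compounds named here, no measured step introduces an ethoxycarbonyl, so the size of its effect rests on that single precedent and on the flat picture across compounds 1, 2 and 3. The step from compound 2 to compound 4 is therefore expected to stay within the scatter, a number 2 percentage points higher from compound 2 to compound 4 (within the scatter). Compound 4 is thus estimated to give 2% in this assay, with a range from 0% to 15%.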

Compound 4, a percentage reported as inhibition, at one concentration (the size of the read-out at that concentration, not a potency): 0%
Estimate against measurement, compound 4: 2 percentage points above, and the stated range covers the measured number.
By their numbers in this assay, from the lowest: compounds 1, 2, 3 and 4 (each within the scatter of the next).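

In this assay, the exchange at this aromatic carbon, next to the ring nitrogen, gives no change at the digits printed from compound 2 to compound 4 (within the scatter) when ethoxycarbonyl replaces furan-2-yl, and no change at the digits printed from compound 3 to compound 4 (within the scatter) when it replaces methyl. Among the compounds shown here, until now, the only measured step at this position had put a methyl in place of furan-2-yl; the ethoxycarbonyl adds a group with no ring, a double bond outside aromatic rings and two hydrogen-bond acceptors, and the reading still does not separate from those of compound 2 and compound 3. No measurement shown here accounts for this flat result.

With all the compounds shown sitting at the same printed reading, they give no direction of change at this position and no sign of which groups here, if any, would lift the inhibition at the concentration tested. On these data alone, whether an amine, a carboxylic acid or a longer chain on this carbon would move the number away from that shared reading remains open, as does the effect of any change elsewhere on the shared core.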